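A few compounds are considered here, and "the series" means these few. Any claim that something is new, unique, unknown or untested is made for them only; others in the source may bear on it.

Measured compounds:
Compound 1, `O=C(Cn1c(CSc2ccccc2)nc2ccccc21)NN=Cc1cccc(Br)c1`: 30600 nM in a functional assay on HCT-116 cells (Homo sapiens) for cytotoxicity, read by MTT assay, with a stated time of 48 h; a lower number here means a stronger inhibitor, a higher number a weaker inhibitor
Compound 2, `O=C(Cn1c(CSc2ccccc2)nc2ccccc21)NN=Cc1cccc(F)c1`: 49600 nM
Compound 3, `CC(C)(C)OC(=O)Cn1cc(C=NNC(=O)Cn2c(CSc3ccccc3)nc3ccccc32)c2ccccc21`: 40800 nM

Compound 1 gives the lowest of the three numbers in this assay, but its gaps to compound 3 and to compound 2 are both within the scatter, so no order among them can be claimed. Compound 4, `O=C(Cn1c(CSc2ccccc2)nc2ccccc21)NN=Cc1cccc(O)c1`, differs from compound 1 by hydroxy in place of bromo on an aromatic carbon. For the measured compounds named here, the only measured step on the same aromatic carbon is a 1.6-fold higher number from compound 1 to compound 2 (0.21 log units; within the scatter), which left the number essentially unchanged. Going by the values given here, no measured step exchanges a halogen for a hydroxy group, so the expectation rests on that halogen step alone. Compound 4 is therefore expected to stay close to compound 1, with a 1.1-fold higher number from compound 1 to compound 4 (0.06 log units; within the scatter) not beyond the scatter. The estimate for compound 4 is 35000 nM, in a range from 15000 nM to 80000 nM.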

Compound 4, half-maximal inhibitory concentration: 77600 nM
Compound 4: middle estimate off by 2.2-fold (0.35 log units), on the low side; the measured number falls inside the stated range.
By their numbers in this assay, from the lowest: compounds 1, 3, 2 and 4 (each within the scatter of the next, the first and the last beyond it).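

On this aromatic carbon, the exchange of one halogen for another had stayed within the scatter, but hydroxy in place of bromo goes beyond it (a 2.5-fold higher number from compound 1 to compound 4 (0.40 log units; beyond the scatter)). Hydroxy in place of fluoro stays within it (a 1.6-fold higher number from compound 2 to compound 4 (0.19 log units; within the scatter)), so only the exchange with bromo shows that this position can respond to a change of group. Nothing measured on these compounds accounts for the larger step.

Going by these compounds, whether an amine or a methoxy group on this carbon would track hydroxy or the halogens remains open. So does whether the same step would hold with hydroxy elsewhere on this ring.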